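This account rests on a few compounds, and the source may have more. Where it says the series, first, only, none or still open, it means among the compounds named here.

Compound 1 `Cc1ccccc1-n1nncc1CN1C(=O)C2(C(C#N)=C(N)Oc3c(N)cc4nc5ccccc5nc4c32)c2ccccc21` and compound 2 `N#CC1=C(N)Oc2c(N)cc3nc4ccccc4nc3c2C12C(=O)N(Cc1cnnn1-c1ccccc1Br)c1ccccc12` share one core and differ only at the aryl group on the triazole nitrogen. In a functional assay on A549 cells (Homo sapiens) for antiproliferative activity, read by MTT assay, with a stated time of 48 h (on this read-out higher numbers stand for weaker inhibition and lower numbers for stronger inhibition), compound 1 gives 31700 nM, and compound 2 gives 27400 nM. The change between them, a 1.2-fold lower number from compound 1 to compound 2 (0.06 log units; within the scatter), leaves the read-out where it was. Compound 2 therefore stands at the lower of the two numbers, but with compound 1 within the scatter of it, so no order between the two can be claimed.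

Compound 3 `N#CC1=C(N)Oc2c(N)cc3nc4ccccc4nc3c2C12C(=O)N(Cc1cnnn1-c1cccc(C(F)(F)F)c1)c1ccccc12` carries the change (3-(trifluoromethyl)phenyl in place of 2-bromophenyl on an aromatic nitrogen). Going by the values given here, only one measured step bears on it: the exchange of methyl for bromo on the same aryl ring, which was within the scatter. Among the compounds with values here, no measured pair shows what moving a substituent to the other position of that ring, or bringing in a trifluoromethyl group, does on this core. On that ground the step of a 1.0-fold lower number from compound 2 to compound 3 (0.01 log units; within the scatter) is expected to stay within the scatter, with no direction favoured. For compound 3 the value in this assay is estimated at 27000 nM, within a range from 10000 nM to 75000 nM.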

Compound 3, half-maximal inhibitory concentration: 5400 nM
Beside the measured number, compound 3's estimate is 5.0-fold (0.70 log units) above it; the whole stated range lies above it.
By their numbers in this assay, from the lowest: compound 3; then compounds 2 and 1 (each within the scatter of the next).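

The aryl group on the aromatic nitrogen is not a silent position on this core: the swap of methyl for bromo left the read-out in this assay unmoved, but the new aryl group gives a 5.1-fold lower number from compound 2 to compound 3 (0.71 log units; beyond the scatter) and a 5.9-fold lower number from compound 1 to compound 3 (0.77 log units; beyond the scatter). Both steps are modest, yet they show that this position can move the antiproliferative read-out, and that 3-(trifluoromethyl)phenyl reads differently from both 2-bromophenyl and 2-methylphenyl. Nothing given here accounts for the difference.

Each step changes the substituent and its place on the aryl ring at once, so the compounds shown cannot say whether the lower number goes with the trifluoromethyl group itself or with its place; a 3-bromophenyl or a 2-(trifluoromethyl)phenyl group on the same core would separate the two. On these data alone, how far the position tolerates other kinds of group, such as an amine or a carboxylic acid on that ring, or a plain unsubstituted phenyl, also remains open.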